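This account rests on a few compounds, and the source may have more. Where it says the series, first, only, none or still open, it means among the compounds named here.

Measured so far in a functional assay on MCF7 cells (Homo sapiens) for cytotoxicity, read by MTT assay, with a stated time of 48 h; on this read-out lower numbers stand for stronger inhibition and higher numbers for weaker inhibition:
- Compound 1 `COc1ccc(NC(=S)N/N=C\c2ccnc3ccccc23)cc1`: 990 nM
- Compound 2 `CCc1ccc(NC(=S)N/N=C\c2ccnc3ccccc23)cc1`: 820 nM
- Compound 3 `S=C(N/N=C\c1ccnc2ccccc12)Nc1ccc(Cl)cc1`: 1070 nM

In this assay, compound 3 gives 1070 nM and stands level with the other two compounds, as a 1.1-fold higher number from compound 1 to compound 3 (0.03 log units; within the scatter) and a 1.3-fold higher number from compound 2 to compound 3 (0.12 log units; within the scatter) show. The remaining pair behaves alike, with a 1.2-fold lower number from compound 1 to compound 2 (0.08 log units; within the scatter).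

Compound 4 `C=CCNC(=S)N/N=C\c1ccnc2ccccc12` has not yet been measured. It carries allyl in place of 4-chlorophenyl on an amide-type nitrogen.

The three measured steps bear on this change only loosely. Each exchanges one group on an aromatic carbon and leaves the rest of the substituent on the nitrogen in place, whereas here the whole 4-chlorophenyl leaves. Their small size therefore sets no firm limit on the new step, and they give no direction. Within the data shown here, the data hold no compound that lacks this aromatic substituent. A moderate step toward a higher number in this assay is tentatively expected, with a range wide enough to include no real change. The expected step is a 1.7-fold higher number from compound 3 to compound 4 (0.23 log units; within the scatter). For compound 4 the estimated value is 1800 nM, with an expected range of 550 nM to 6000 nM.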

Compound 4, half-maximal inhibitory concentration: 970 nM
The estimate for compound 4 lay 1.9-fold (0.27 log units) above the measured number; the measured number falls inside the stated range.
By their numbers in this assay, from the lowest: compounds 2, 4, 1 and 3 (each within the scatter of the next).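

In this assay the whole aromatic substituent on the amide-type nitrogen can give way to allyl with no step beyond the scatter: the exchange gives a 1.1-fold lower number from compound 3 to compound 4 (0.04 log units; within the scatter) and a 1.2-fold higher number from compound 2 to compound 4 (0.07 log units; within the scatter) and also a 1.0-fold lower number from compound 1 to compound 4 (0.01 log units; within the scatter) for the three aryl compounds. Among these compounds, the earlier steps changed only one group on an aromatic carbon and kept the six-membered aromatic ring in place, so they could not show that compound 4, which has no ring at that nitrogen and carries 3 heavy atoms there in place of the 7 of 4-chlorophenyl, stands level with the aryl compounds 1, 2 and 3 on this read-out. Nothing available explains why the numbers stay level across this large exchange.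

As far as these compounds go, it remains open whether a longer chain such as hexyl, a benzyl group or a chain ending in a carboxylic acid on the amide-type nitrogen would also stand level with these four compounds. It also remains open whether the double bond of allyl plays any part, since a saturated propyl group is not among the compounds shown.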